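The compounds below may be only part of what the source reports. "The series", "measured", "known", "first", "only" and "open" are said of these compounds alone.

Of the compounds shown here, three have so far been tested in an assay for inhibition of 3-hydroxy-3-methylglutaryl-coenzyme A reductase (Rattus norvegicus); on this read-out higher numbers stand for weaker inhibition and lower numbers for stronger inhibition. Compound 1, `COc1ccc(-c2cc(Cl)cc(Cl)c2/C=C/[C@@H]2C[C@@H](O)CC(=O)O2)cc1`, gives 470 nM. Compound 2, `Cc1cc(-c2cccc(Cl)c2/C=C/[C@@H]2C[C@@H](O)CC(=O)O2)ccc1F`, gives 30 nM. Compound 3, `Cc1cc(C)c(/C=C/[C@@H]2C[C@@H](O)CC(=O)O2)c(-c2ccc(F)cc2)c1`, gives 13 nM, the lowest number of the three; compound 2 stands nearest to it, with a gap that goes beyond the usual scatter, and compound 1 stands furthest away. Compound 4, `Cc1cc(C)c(/C=C/[C@@H]2C[C@@H](O)CC(=O)O2)c(-c2cc(C)c(F)c(C)c2)c1`, has not yet been measured. It differs from compound 3 in one place: 4-fluoro-3,5-dimethylphenyl in place of 4-fluorophenyl on an aromatic carbon. Among the compounds with values here, no pair among the measured compounds differs by this kind of change alone, so there is no measured step to lean on, and the comparison rests on the structures only. The change is a modest one, and the expectation is that the step of a 1.9-fold higher number from compound 3 to compound 4 (0.28 log units; within the scatter) stays small, with a slight lean toward a higher number. The value of compound 4 in this assay is therefore estimated at 25 nM, with a likely range from 8 nM to 80 nM.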

Compound 4, half-maximal inhibitory concentration: 10 nM
Compound 4: the middle estimate sits 2.5-fold (0.40 log units) above what was measured, within the range that was stated.
By their numbers in this assay, from the lowest: compounds 4 and 3 (each within the scatter of the next); then compound 2; then compound 1.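

Within the data shown here, compounds 1 to 3 offered no pair differing in one place, so this is the first direct reading of a single change at this position. In this assay, placing 4-fluoro-3,5-dimethylphenyl where 4-fluorophenyl stood gives a 1.3-fold lower number from compound 3 to compound 4 (0.11 log units; within the scatter), so the assay does not tell these two groups apart, and the two methyl groups can be present on this aromatic carbon's substituent without a measurable cost. Nothing available explains why the two groups read alike.

The compounds shown leave open whether an amine, a hydroxyl group or a carboxylic acid in the places of those two methyl groups would read the same way. They also leave open what happens when the fluorine of this group gives way to a chlorine or a hydrogen while both methyl groups stay.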